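A few compounds are considered here, and "the series" means these few. Any claim that something is new, unique, unknown or untested is made for them only; others in the source may bear on it.

Measured compounds:
compound 1, `CC[C@@H]1C(=O)N(C)c2cnc(Nc3ccc(S(=O)(=O)NCCO)cc3)nc2N1C1CCCC1`: 459 nM
compound 2, `CCC1C(=O)N(C)c2cnc(-n3ccc4cc(C(=O)NCC(C)C)ccc43)nc2N1c1ccn(C)n1`: 4970 nM
compound 3, `CC[C@@H]1C(=O)N(C)c2cnc(Nc3ccc(S(=O)(=O)NCCCO)cc3)nc2N1C1CCCC1`: 357 nM

In a functional assay on HeLa cells (Homo sapiens) for antiproliferative activity, read by CCK-8 assay, with a stated time of 72 h (a lower number here means a stronger inhibitor of growth, a higher number a weaker inhibitor of growth), compound 2 stands highest of the three numbers, beyond the scatter above both compound 1 and compound 3, and it is the only one built on its own core; compound 1 and compound 3 share a different core. Compound 4, `CCCNC(=O)c1ccc2c(ccn2-c2ncc3c(n2)N(c2ccn(C)n2)C(CC)C(=O)N3C)c1`, differs from compound 2 in a single place: hydrogen in place of methyl on a saturated chain carbon bound to two saturated chain carbons.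

Within the data shown here, the one measured step here, a 1.3-fold lower number from compound 1 to compound 3 (0.11 log units; within the scatter), lies within the scatter; it concerns a chain on the core of compound 1 and compound 3 and does not bear directly on trimming a methyl from the amide chain of compound 2. Among the measured compounds shown here, with no step that matches this change, the expectation rests on the smallness of the change itself: a single carbon leaves a saturated chain. The expected step is a 1.1-fold lower number from compound 2 to compound 4 (0.04 log units; within the scatter), none beyond the scatter. Compound 4 is therefore estimated at 4500 nM, with a range from 1800 nM to 11000 nM.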

Compound 4, concentration for 50% growth inhibition: 6160 nM
Compound 4: the middle estimate sits 1.4-fold (0.14 log units) below what was measured, within the range that was stated.
By their numbers in this assay, from the lowest: compounds 3 and 1 (each within the scatter of the next); then compounds 2 and 4 (each within the scatter of the next).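

In this assay the change from isobutyl to propyl leaves the number within the scatter (a 1.2-fold higher number from compound 2 to compound 4 (0.09 log units; within the scatter)), so the methyl on a saturated chain carbon bound to two saturated chain carbons can be removed without a measurable effect in this assay. Among these compounds, this is the first measured step on the core of compound 2, since the earlier step belonged to the core of compound 1 and compound 3. Nothing measured here offers an explanation for this result.

As far as these compounds go, whether a longer chain, a ring, or a chain ending in an amine or a carboxylic acid would also stay within the scatter of compound 2 remains open. Also open, from the compounds shown here alone, is whether the same change would have as small an effect on a different core.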